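The source may report more compounds than this note shows. Statements on the series, on what has been measured and on what is new or still open speak of the compounds shown alone.

Compounds measured so far in a functional assay on K562 cells (Homo sapiens) for cytotoxicity, read by MTT assay, with a stated time of 24 h (a higher number here means a weaker inhibitor, a lower number a stronger inhibitor), are these:

compound 1 `COc1ccc(/C=C2\CN(C)C/C(=C\c3ccccc3F)C2=O)cc1` gives 18400 nM
compound 2 `CN1C/C(=C\c2ccc(C(C)(C)C)cc2)C(=O)/C(=C/c2ccccc2F)C1` gives 18200 nM
compound 3 `COc1cc(/C=C2\CN(C)C/C(=C\c3ccc(Cl)cc3)C2=O)cc(OC)c1` gives 13300 nM

Compound 3 lies within the scatter of both compound 1 and compound 2, so the three values show no order among them. Compound 4 `COc1cc(/C=C2\CN(C)C/C(=C\c3ccc(Cl)c(Cl)c3)C2=O)cc(OC)c1` differs from compound 3 by a single change, (chloro in place of hydrogen on an aromatic carbon), which is chloro in place of hydrogen on an aromatic carbon and turns 4-chlorophenyl to 3,4-dichlorophenyl. Going by the values given here, the only measured step, a 1.0-fold lower number from compound 1 to compound 2 (0.00 log units; within the scatter), is tert-butyl in place of methoxy on an aromatic carbon. Among the compounds with values here, it lies within the scatter and sits on a different group, so it bears on this change only indirectly, and no measured step adds a chloro. With compound 3 at 13300 nM as the anchor, no shift beyond the scatter is expected. The expected step is a 1.1-fold lower number from compound 3 to compound 4 (0.04 log units; within the scatter) and no firm direction is expected for it. In this assay the estimated value for compound 4 is 12000 nM, with an expected range from 6000 nM to 24000 nM.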

Compound 4, half-maximal inhibitory concentration: 9490 nM
The estimate for compound 4 lay 1.3-fold (0.10 log units) above the measured number; the measured number falls inside the stated range.
By their numbers in this assay, from the lowest: compounds 4, 3, 2 and 1 (each within the scatter of the next).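

In this assay, going from 4-chlorophenyl to 3,4-dichlorophenyl gives a 1.4-fold lower number from compound 3 to compound 4 (0.15 log units; within the scatter). Going by these compounds alone, this is the first measured change at this aromatic carbon, ortho to a chloro group and meta to a large group, and it shows that a chloro can stand there without a shift that can be told from the scatter. The earlier step concerned a different place and a different exchange, tert-butyl for methoxy, so it said nothing about this position, and no supporting measurement is available to explain the result. The compounds shown leave open whether an amine, a carboxylic acid or a longer chain on this same carbon would move the number beyond the scatter. They also leave open whether adding a chloro here gives a similar step when the other aromatic ring carries something other than its two methoxy groups.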